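Oxamide Swap: Tert-Butyl to 4-Hydroxyphenyl

The compounds below may be only part of what the source reports. "The series", "measured", "known", "first", "only" and "open" are said of these compounds alone.

Compound 3 `CC(C)(C)NC(=O)C(=O)Nc1ccc2c(c1)COC2=O` gives the highest number among the three measured, with 3400 nM in a functional assay on cells (T-cell, Mus musculus) for inhibition; a higher number here means a weaker inhibitor, a lower number a stronger inhibitor. Compound 2 `CC(C)c1ccc(/C=C/C(=O)Nc2ccc3c(c2)COC3=O)cc1` stands nearest to it with 1590 nM, a gap beyond the scatter, while compound 1 `COc1ccccc1/C=C/C(=O)Nc1ccc2c(c1)COC2=O` stands furthest away with 39 nM, also beyond the scatter. Compound 4 `O=C(Nc1ccc(O)cc1)C(=O)Nc1ccc2c(c1)COC2=O` has not yet been measured. Its change from compound 3 is 4-hydroxyphenyl in place of tert-butyl on an amide-type nitrogen. Within the data shown here, no measured pair shows this change, so its effect is unknown from the present data. Compound 4 is expected to give a somewhat lower number than compound 3, a modest step downward a 2.3-fold lower number from compound 3 to compound 4 (0.36 log units; beyond the scatter), though the uncertainty is wide. Compound 4 is estimated at 1500 nM, with a range from 300 nM to 8000 nM.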

Compound 4, half-maximal inhibitory concentration: 5030 nM
Beside the measured number, compound 4's estimate is 3.4-fold (0.53 log units) below it; measured number inside the range.
By their numbers in this assay, from the lowest: compound 1; then compound 2; then compounds 3 and 4 (each within the scatter of the next).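

In this assay, 4-hydroxyphenyl in place of tert-butyl on an amide-type nitrogen gives a 1.5-fold higher number from compound 3 to compound 4 (0.17 log units; within the scatter). Among these compounds, this is the first measured change at this position, and it leaves the two groups indistinguishable in this read-out, although the entering group brings an aromatic ring and a hydrogen-bond donor and acceptor that tert-butyl lacks.

As far as these compounds go, whether a plain phenyl, an amine-bearing phenyl or a longer chain on this nitrogen would shift the number remains open. Nothing available explains why this exchange produced no clear change.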